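A Hydroxy Group on the Aryl Ether of Compound 1

This account rests on a few compounds, and the source may have more. Where it says the series, first, only, none or still open, it means among the compounds named here.

Compound 1 `CCN(Cc1cccs1)C(=O)COc1ccc(C)cc1`: 8 nM
Compound 2 `CCN(Cc1ccccc1)C(=O)COc1ccc(C)cc1`: 1880 nM

In an assay on HEK293 cells for agonist activity at transient receptor potential cation channel subfamily M member 8 (Homo sapiens), read by fluorescence and calcium flux, with a stated time of 15 min (a higher number here means that more compound is needed for the effect, a lower number that less compound is needed), compound 1 gives 8 nM, the lowest of the two numbers. The nearest is compound 2, which gives 1880 nM, reached by a 240-fold higher number from compound 1 to compound 2 (2.37 log units; beyond the scatter). Compound 3 `CCN(Cc1cccs1)C(=O)COc1ccc(C)cc1O` differs from compound 1 by hydroxy in place of hydrogen on an aromatic carbon, ortho to a large group and meta to a methyl group. Among the compounds with values here, the only measured step concerns the group on the saturated chain carbon bound to the amide-type nitrogen, not this ring, so no measured step bears on this change, and no step beyond the scatter is expected in this assay. Compound 3 is therefore expected to give about 15 nM, between 3 nM and 80 nM. The expected step is a 1.9-fold higher number from compound 1 to compound 3 (0.27 log units; within the scatter).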

Compound 3, half-maximal effective concentration: 8 nM
The estimate for compound 3 lay 1.9-fold (0.27 log units) above the measured number; measured number inside the range.
By their numbers in this assay, from the lowest: compounds 1 and 3 (each within the scatter of the next); then compound 2.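

In this assay, hydroxy in place of hydrogen on this aromatic carbon, ortho to a large group and meta to a methyl group, gives no change at the digits printed from compound 1 to compound 3 (within the scatter) and so leaves the number of compound 1 in place. The earlier step, a 240-fold higher number from compound 1 to compound 2 (2.37 log units; beyond the scatter) on replacing thiophen-2-yl with phenyl, said nothing about this ring, whereas this result shows that the ring carbon carries hydroxy without a step beyond the scatter. Nothing at hand gives a reason for this result. From the compounds shown here alone, whether a methoxy group, an amine or a carboxylic acid on the same carbon would also leave the number in place stays open.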